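A larger group on the sulfonamide nitrogen

This account rests on a few compounds, and the source may have more. Where it says the series, first, only, none or still open, it means among the compounds named here.

Compound 2 `CCNC(=O)NS(=O)(=O)c1ccc(-n2nc(C(=O)O)cc2C)cc1` and compound 1 `CCNC(=S)NS(=O)(=O)c1ccc(-n2nc(C(=O)O)cc2C)cc1` share one core and differ only in the group on a sulfonamide nitrogen. In a functional assay on the whole organism (blood, strain albino) with Mus musculus as the target, with stated times of 6 days and 4 h, at a dose of 0.4 mmol/kg by the oral route (a lower number here means less inhibition, a higher number more inhibition at the dose given (going by the name of the read-out)), compound 1 gives -2%, and compound 2 gives 0%. Of these two numbers compound 2 stands highest, with compound 1 nearest, but the step of a number 2 percentage points higher from compound 1 to compound 2 (within the scatter) lies within the scatter, so the two values cannot be told apart.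

Compound 3 `Cc1cc(C(=O)O)nn1-c1ccc(S(=O)(=O)NC(=S)Nc2ccccc2)cc1` has not yet been measured. Relative to compound 2 the change is a group of 9 heavy atoms (7 carbon, 1 nitrogen, 1 sulfur; one six-membered aromatic ring of carbon only) in place of a group of 5 heavy atoms (3 carbon, 1 nitrogen, 1 oxygen; no ring), on a sulfonamide nitrogen. Among the compounds with values here, only one measured step bears on this change, a number 2 percentage points higher from compound 1 to compound 2 (within the scatter), which shows that swapping a group holding oxygen for one of the same size holding sulfur left the read-out unchanged. Within the data shown here, the present change is larger: a ring enters, and no measured pair speaks to that part of it. With both measured values near zero, the expectation is no step beyond the scatter in this assay, so the estimated step is a number 5 percentage points higher from compound 2 to compound 3 (within the scatter). Compound 3 is therefore estimated at 5%, with a range from -15% to 30%.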

Compound 3, a percentage reported as inhibition, in the whole organism at one dose (the size of the read-out at that dose, not a potency): 0%
Beside the measured number, compound 3's estimate is 5 percentage points above it; measured number inside the range.
By their numbers in this assay, from the lowest: compounds 1, 2 and 3 (each within the scatter of the next).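

Phenyl in place of ethyl on an amide-type nitrogen gives a number 2 percentage points higher from compound 1 to compound 3 (within the scatter) in this assay, so this position now has a test of the end of the group as well as the earlier swap of oxygen for sulfur. The full exchange of ethylcarbamoyl for the larger group carrying a six-membered aromatic ring and sulfur gives no change at the digits printed from compound 2 to compound 3 (within the scatter) and so also stays within the scatter, which means that neither a ring nor the larger group on the sulfonamide nitrogen separates these compounds in this read-out. No information is available that could explain why the three numbers cannot be told apart.

As far as these compounds go, it remains open whether any group on this nitrogen can move the read-out beyond the scatter, for instance a longer chain such as hexyl or a saturated ring such as cyclohexyl in place of the phenyl of compound 3. Also open, from the compounds shown here alone, are the oxygen counterpart of compound 3, phenylcarbamoyl on the sulfonamide nitrogen, and an ethyl ester in place of the carboxylic acid on the shared core.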